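A few compounds are considered here, and "the series" means these few. Any claim that something is new, unique, unknown or untested is made for them only; others in the source may bear on it.

In an in vitro functional assay on 1321-N1 cells for agonist activity at Free fatty acid receptor 1 (Homo sapiens), read by fluorescence, spectrophotometry and calcium flux (a higher number here means that more compound is needed for the effect, a lower number that less compound is needed), three compounds have already been measured. Compound 1 `Cc1c(C#Cc2ccc(CCC(=O)O)cc2)cc(Cl)nc1Cl` gives 43.7 nM, and compound 2 `O=C(O)CCc1ccc(C#Cc2cc(Cl)nc(Cl)c2)cc1` gives 40.7 nM. These two differ in a single place, (methyl in place of hydrogen on an aromatic carbon), and the step of a 1.1-fold higher number from compound 2 to compound 1 (0.03 log units; within the scatter) shows that this change made no real difference to the result. Compound 3 `O=C(O)CCc1ccc(C#Cc2ccncc2)cc1` is built on a different core; the difference between its core and that of compound 2 is not broken down here. In this assay compound 3 gives 4070 nM, the highest of the three numbers, beyond the scatter from both compound 1 and compound 2.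

Compound 4 `Cc1cc(C#Cc2ccc(CCC(=O)O)cc2)ccn1` has not yet been measured. It stands to compound 3 as compound 1 stands to compound 2: methyl in place of hydrogen on an aromatic carbon. The surroundings of the change are not the same, though. In compound 1 the methyl sits ortho to a chloro group, ortho to a large group, two atoms from the ring nitrogen and para to a chloro group, whereas in compound 4 it sits next to the ring nitrogen and meta to a large group. It is therefore the same kind of change, not the same change. Because the step of a 1.1-fold higher number from compound 2 to compound 1 (0.03 log units; within the scatter) lay within the scatter, a step of similar smallness is expected here: a 1.2-fold lower number from compound 3 to compound 4 (0.07 log units; within the scatter). Compound 4 is accordingly estimated at 3500 nM, with an expected range from 1200 nM to 10000 nM.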

Compound 4, half-maximal effective concentration: 1120 nM
Compound 4: middle estimate off by 3.1-fold (0.49 log units), on the high side; the whole stated range lies above it.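

In this assay, putting a methyl in place of hydrogen on the core of compound 3 gives a 3.6-fold lower number from compound 3 to compound 4 (0.56 log units; beyond the scatter), a modest step, but one that means less compound is needed for the effect. The same kind of change did not keep its size when carried from one core to the other: the same change on two cores in this assay, a 1.1-fold higher number (0.03 log units; within the scatter) from compound 2 to compound 1 and a 3.6-fold lower number (0.56 log units; beyond the scatter) from compound 3 to compound 4, 3.9-fold (0.59 log units) apart, beyond the scatter of two such steps. This shows that a result for this change on one core of the series cannot simply be copied to the other, but it does not show why: the two methyl groups differ in their surroundings as well as in their cores, and two pairs of compounds give no rule for any further core.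

The compounds shown leave open whether the two cores would agree if the methyl stood in matching surroundings on both, and whether a methyl elsewhere on the ring of compound 3 would give a similar step. They also leave open whether the step belongs to methyl in particular, or whether an ethyl, a methoxy group or an amine in the same place on the ring would give a similar result.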